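Aryl change on the benzyl arm toward compound 4

The source may report more compounds than this note shows. Statements on the series, on what has been measured and on what is new or still open speak of the compounds shown alone.

Compound 2 `CCCn1c(=O)c2nc(-c3cnn(Cc4cc(F)ccc4Cl)c3)[nH]c2n(CCC)c1=O` holds the highest of the two numbers in an in vitro assay on HEK293 cells for displacement of a labelled ligand from adenosine receptor A2b (Homo sapiens) (on this read-out higher numbers stand for weaker inhibition and lower numbers for stronger inhibition), at 4800 nM. Among the compounds with values here, its nearest neighbour, compound 1 `CCCn1c(=O)c2nc(-c3cnn(Cc4cccc(C)c4)c3)[nH]c2n(CCC)c1=O`, gives 36 nM in this assay, and the step of a 130-fold higher number from compound 1 to compound 2 (2.12 log units; beyond the scatter) is the only measured step here, made at the same saturated chain carbon bound to an aromatic nitrogen. Compound 3 `CCCn1c(=O)c2nc(-n3cccn3)[nH]c2n(CCC)c1=O` gives only a limit in this assay, > 5800 nM. Compound 4 `CCCn1c(=O)c2nc(-c3cnn(Cc4c(F)cc(F)cc4F)c3)[nH]c2n(CCC)c1=O` differs from compound 2 by 2,4,6-trifluorophenyl in place of 2-chloro-5-fluorophenyl on a saturated chain carbon bound to an aromatic nitrogen. With one measured step of that size to lean on, and fluorine again counted in the entering group, only a modest step is expected: a 1.6-fold lower number from compound 2 to compound 4 (0.20 log units; within the scatter). Compound 4 is estimated at 3000 nM, range 600 nM to 15000 nM, a limit being possible given (the limit of > 5800 nM in this assay, at which 1 of the 3 values shown sits).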

Compound 4, inhibition constant: 650 nM
Compound 4: the middle estimate sits 4.6-fold (0.66 log units) above what was measured; the measured number falls inside the stated range.
By their numbers in this assay, from the lowest: compound 1; then compound 4; then compound 2. At a limit, above all of these: compound 3.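

In this assay, a halogenated aryl ring on this saturated chain carbon is not fixed at the weak end of the series: a 7.4-fold lower number from compound 2 to compound 4 (0.87 log units; beyond the scatter). The 3-methylphenyl group still holds the lowest number, as an 18-fold higher number from compound 1 to compound 4 (1.26 log units; beyond the scatter) shows. Nothing shown gives a reason for either step. Chlorine leaves and the fluorine pattern changes in the same step, so the compounds shown do not separate those two changes. As far as these compounds go, whether a plain phenyl or pyridine ring at this place would come closer to compound 1 stays open.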